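The source may hold more compounds than are shown below. What is called first, only, known or untested is meant among the compounds shown, and "the series" means these compounds.

In a functional assay on HL-60 cells (Homo sapiens) for antiproliferative activity, read by MTT assay, with a stated time of 72 h (on this read-out lower numbers stand for stronger inhibition and higher numbers for weaker inhibition), the measured compounds read:
Compound 1 `COc1cc(-c2nc(N(C)C)sc2-c2ccc(C)cc2)cc(OC)c1OC`: 3480 nM
Compound 2 `COc1ccc(-c2sc(N(C)C)nc2-c2cc(OC)c(OC)c(OC)c2)cc1`: 1890 nM
Compound 3 `COc1cc(-c2nc(C)sc2-c2ccc(C)cc2)cc(OC)c1OC`: 1510 nM

Compound 2 and compound 3 lie within the scatter of each other, and the gap on the higher side is a 2.3-fold lower number from compound 1 to compound 3 (0.36 log units; beyond the scatter). Compound 4 `COc1ccc(-c2sc(C)nc2-c2cc(OC)c(OC)c(OC)c2)cc1` differs from compound 3 by methoxy in place of methyl on an aromatic carbon. This same swap has been measured once, as a 1.8-fold lower number from compound 1 to compound 2 (0.27 log units; within the scatter), and that step stays within the scatter. For the measured compounds named here, it is the only measured step that bears directly on this one, so a slight move towards a lower number in this assay is expected, with nothing beyond the scatter. The expected step is a 1.5-fold lower number from compound 3 to compound 4 (0.18 log units; within the scatter). For compound 4 the estimated value is 1000 nM, with an expected range from 400 nM to 2500 nM.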

Compound 4, half-maximal inhibitory concentration: 3430 nM
The estimate for compound 4 lay 3.4-fold (0.54 log units) below the measured number, and the stated range ends below it.
By their numbers in this assay, from the lowest: compounds 3, 2, 4 and 1 (each within the scatter of the next, the first and the last beyond it).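

In this assay, the change from 4-methylphenyl to 4-methoxyphenyl gives a 2.3-fold higher number from compound 3 to compound 4 (0.36 log units; beyond the scatter) when methyl rather than dimethylamino is the other group, so its outcome depends on that group: the same change on two cores in this assay, a 1.8-fold lower number (0.27 log units; within the scatter) from compound 1 to compound 2 and a 2.3-fold higher number (0.36 log units; beyond the scatter) from compound 3 to compound 4, 4.2-fold (0.62 log units) apart, beyond the scatter of two such steps

Methyl in place of dimethylamino, read with 4-methoxyphenyl present, gives a 1.8-fold higher number from compound 2 to compound 4 (0.26 log units; within the scatter), which does not repeat its earlier step: the same change on two cores in this assay, a 2.3-fold lower number (0.36 log units; beyond the scatter) from compound 1 to compound 3 and a 1.8-fold higher number (0.26 log units; within the scatter) from compound 2 to compound 4, 4.2-fold (0.62 log units) apart, beyond the scatter of two such steps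

Across these four compounds, the two changes therefore do not add up independently. Going by these compounds, it remains open whether this dependence extends to a hydroxyl group or a fluorine atom at the place of the methoxy, or to an ethyl group in place of the methyl.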